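The source may hold more compounds than are shown below. What is called first, only, known or untested is meant among the compounds shown, and "the series" means these compounds.

Among the measured compounds shown here, in a functional assay on MCF7 cells (Homo sapiens) for cytotoxicity, read by MTT assay and propidium iodide staining, with a stated time of 24 h (a lower number here means a stronger inhibitor, a higher number a weaker inhibitor), compound 1 (`Cc1ccc(-c2nnc(SCC(=O)c3ccc(Br)cc3)o2)c(O)c1`) gives 2070 nM and stands highest of the two numbers so far. For the measured compounds named here, compound 2 (`COc1ccc(-c2nnc(SCC(=O)c3ccc(Br)cc3)o2)c(O)c1`) gives 260 nM in this assay and is the only neighbour. Going by the values given here, the one measured step is an 8.0-fold lower number from compound 1 to compound 2 (0.90 log units; beyond the scatter) for methoxy in place of methyl on an aromatic carbon.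

Compound 3 (`COc1ccccc1-c1nnc(SCC(=O)c2ccc(Br)cc2)o1`) has not been measured. On the shared core, 2-methoxyphenyl stands in place of 2-hydroxy-4-methylphenyl on an aromatic carbon of the five-membered aromatic ring (2-methoxyphenyl in place of 2-hydroxy-4-methylphenyl on an aromatic carbon), so the entering group has 0 hydrogen-bond donors. Among the compounds with values here, the measured step bears on this only in part: compound 3 also carries a methoxy group, but no measured step covers the loss of the hydroxy group or of the methyl group without methoxy replacing it at the same place. Only a fraction of the measured step is therefore carried over, with wide uncertainty.

The expected change is small and towards a lower number, estimated as a 1.9-fold lower number from compound 1 to compound 3 (0.27 log units; within the scatter) in this assay for now. The estimated value for compound 3 is 1100 nM with an expected range (300 nM to 4000 nM).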

Compound 3, half-maximal inhibitory concentration: 600 nM
Compound 3: middle estimate off by 1.8-fold (0.26 log units), on the high side; measured number inside the range.
By their numbers in this assay, from the lowest: compound 2; then compound 3; then compound 1.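

In this assay, 2-methoxyphenyl in place of 2-hydroxy-4-methylphenyl on this aromatic carbon of the five-membered ring gives a 3.5-fold lower number from compound 1 to compound 3 (0.54 log units; beyond the scatter), a step beyond the scatter that the earlier pair could not show, since both of those compounds keep the hydroxy group. A hydroxy group on this aryl ring is therefore not needed for a number lower than that of compound 1, and the entering group, with 0 hydrogen-bond donors, is accepted at this place; the two groups hold the same atoms, joined differently, so the gain comes from rearranging those atoms and not from adding any. No measurement available here gives an explanation for this step.

From the compounds shown here alone, the step changes more than one feature at once, so the loss of the hydroxy group, the loss of the methyl group and the arrival of the methoxy group cannot be separated, and how much each contributes remains unknown. Also open, going by these compounds, is whether the aryl group accepts an amine or a carboxylic acid in place of the methoxy group, or a longer chain such as ethoxy.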